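Bromine Removal on a Fused Core: Expected Antiproliferative Read-out

The source may report more compounds than this note shows. Statements on the series, on what has been measured and on what is new or still open speak of the compounds shown alone.

Compound 1, `COc1cc(Br)cc(/C=C/C(=O)c2ccccc2)c1O`, gives 67%.
Compound 2, `COc1cc(Br)cc(/C=C/C(=O)c2ccc(Br)cc2)c1O`, gives 64.6%.
Compound 3, `COC(=O)C1=C(N)Oc2c(OC)cc(Br)cc2C1CC(=O)c1ccc(Cl)cc1`, gives 80.3%.

These three compounds were measured in a functional assay on MCF7 cells (Homo sapiens) for antiproliferative activity, read by sulforhodamine B assay, with a stated time of 72 h, tested at 10 uM; on this read-out higher numbers stand for a weaker effect at the one concentration tested and lower numbers for a stronger effect. Compound 1 and compound 2 share one core; the difference between them is hydrogen in place of bromo on an aromatic carbon, and the resulting step, a number 2.4 percentage points higher from compound 2 to compound 1 (within the scatter), is within the scatter. Compound 3 has a different core, and the difference between the two cores is not broken down here. Compound 3 stands highest of the three, and its gap to compound 1 and to compound 2 lies beyond the scatter.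

Compound 4, `COC(=O)C1=C(N)Oc2c(OC)cccc2C1CC(=O)c1ccc(Cl)cc1`, has not yet been measured. It differs from compound 3 by hydrogen in place of bromo on an aromatic carbon. This is the same kind of change as from compound 2 to compound 1, but not the same: there the bromo sat para to a large group, here it sits on a ring that is part of a fused or bridged system of two rings, meta to a fused ring, meta to a methoxy group and para to a fused ring. Among the measured compounds shown here, the only precedent in this set is a number 2.4 percentage points higher from compound 2 to compound 1 (within the scatter), which is within the scatter. Resting on that single precedent, a similarly small step is expected in this assay, a number 1.7 percentage points higher from compound 3 to compound 4 (within the scatter), though the different surroundings of the change leave room for a larger move. Compound 4 is therefore estimated at 82%, with a range from 66% to 95%.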

Compound 4, a percentage reported as activity, at one concentration (the size of the read-out at that concentration, not a potency): 89.8%
For compound 4 the middle estimate is 7.8 percentage points below the measured one; the measured number falls inside the stated range.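

In this assay, putting hydrogen in place of bromo on an aromatic carbon of the second core gives a number 9.5 percentage points higher from compound 3 to compound 4 (within the scatter). Set beside the earlier step on the core of compound 1, the change does not show a measurable difference between the two cores: the same change on two cores in this assay, a number 2.4 percentage points higher (within the scatter) from compound 2 to compound 1 and a number 9.5 percentage points higher (within the scatter) from compound 3 to compound 4, 7.1 percentage points apart, within the scatter of two such steps. Among the compounds shown here, this shows that, in these two pairs, the exchange stays within the usual scatter on both cores and that nothing here separates its size on one core from its size on the other, but it does not establish a general rule, since it rests on only two pairs, with the bromo in different surroundings, and on a single concentration in a single assay, which gives no potency.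

The compounds shown leave open whether fluoro, a nitrile or a trifluoromethyl group in place of bromo on the same aromatic carbon would also stay within the scatter on either core. They also leave open what the chloro on the outer ring of compound 3 and compound 4 contributes, and whether exchanging it for hydrogen would carry across to the core of compound 1 in the way the bromo exchange does.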